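Replacing 3-phenylpropyl on a carbonyl carbon

The source may hold more compounds than are shown below. What is called first, only, known or untested is meant among the compounds shown, and "the series" means these compounds.

In a functional assay on HepG2 cells (Homo sapiens) for inhibition, read by MTT assay, with a stated time of 48 h (a lower number here means a stronger inhibitor, a higher number a weaker inhibitor), compound 1 `CCC(=O)Nc1ccc(N2CCN(c3ccc(OC[C@@H]4CO[C@@](Cn5cncn5)(c5ccc(Cl)cc5Cl)O4)cc3)CC2)cc1` gives 5460 nM and compound 2 `O=C(CCCc1ccccc1)Nc1ccc(N2CCN(c3ccc(OC[C@@H]4CO[C@@](Cn5cncn5)(c5ccc(Cl)cc5Cl)O4)cc3)CC2)cc1` gives 10800 nM, so these two values lie within the scatter of each other. Compound 3 `O=C(Nc1ccc(N2CCN(c3ccc(OC[C@@H]4CO[C@@](Cn5cncn5)(c5ccc(Cl)cc5Cl)O4)cc3)CC2)cc1)C(/C=C/Cl)C/C=C/C(F)(F)F` differs from compound 2 as follows: 1-(2-chloroethenyl)-5,5,5-trifluoropent-3-en-1-yl in place of 3-phenylpropyl on a carbonyl carbon. Among the compounds with values here, the only measured step, a 2.0-fold higher number from compound 1 to compound 2 (0.30 log units; within the scatter), stays within the scatter, though it involves a different change and offers only limited guidance. No step beyond the scatter is therefore expected in this assay. The expected step is a 1.4-fold lower number from compound 2 to compound 3 (0.13 log units; within the scatter). The estimated value for compound 3 is 8000 nM, with a range of 3000 nM to 20000 nM.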

Compound 3, half-maximal inhibitory concentration: 9570 nM
For compound 3 the middle estimate is 1.2-fold (0.08 log units) below the measured one; the range from low to high includes it.
By their numbers in this assay, from the lowest: compounds 1, 3 and 2 (each within the scatter of the next).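

In this assay, 1-(2-chloroethenyl)-5,5,5-trifluoropent-3-en-1-yl, which has no ring, replaces 3-phenylpropyl on the carbonyl carbon with a 1.1-fold lower number from compound 2 to compound 3 (0.05 log units; within the scatter), so losing the aromatic ring of that group leaves the number within the scatter. Against ethyl, the same group gives a 1.8-fold higher number from compound 1 to compound 3 (0.24 log units; within the scatter), so all three groups shown at this place lie within the scatter of one another. Nothing available explains this result. The compounds shown leave open whether a group of another kind on this carbonyl carbon, such as an amine or a carboxylic acid, would move the number beyond the scatter.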